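The source may report more compounds than this note shows. Statements on the series, on what has been measured and on what is new or still open speak of the compounds shown alone.

Three compounds share one core and differ only in the group on the amide carbonyl. Compound 1 `CC(C)C[C@H](N)c1cc(C(F)(F)F)ccc1N1CCN(C(=O)COc2ccc(Cl)cc2)CC1` gives 2900 nM in an assay on HEK293 cells for displacement of a labelled ligand from Melanocortin receptor 4 (Homo sapiens); a higher number here means a weaker inhibitor, a lower number a stronger inhibitor. Compound 2 `CC(C)C[C@H](N)c1cc(C(F)(F)F)ccc1N1CCN(C(=O)COc2ccc(O)cc2)CC1` gives 4600 nM in this assay, and compound 3 `CC(C)C[C@H](N)c1cc(C(F)(F)F)ccc1N1CCN(C(=O)COc2cccc(Cl)c2)CC1` gives 2600 nM. The three numbers lie close together: a 1.6-fold higher number from compound 1 to compound 2 (0.20 log units; within the scatter), a 1.1-fold lower number from compound 1 to compound 3 (0.05 log units; within the scatter) and a 1.8-fold lower number from compound 2 to compound 3 (0.25 log units; within the scatter), so compound 3 cannot be set apart from its two companions.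

Compound 4 `Cc1cc(Cl)ccc1CC(C)C(=O)N1CCN(c2ccc(C(F)(F)F)cc2[C@@H](N)CC(C)C)CC1` takes a further step from compound 3: 1-(4-chloro-2-methylbenzyl)ethyl in place of (3-chlorophenoxy)methyl on a carbonyl carbon. Going by the values given here, none of the measured steps bears directly on this change; each of them kept the aryl ether and only moved or exchanged a substituent on its ring, and each stayed within the scatter. The change to compound 4 removes the ether oxygen and lengthens the link to the ring, for which the measured compounds offer no guide. Compound 4 is therefore expected to give about 3500 nM in this assay, within a wide range from 900 nM to 14000 nM. The step this estimate means, a 1.3-fold higher number from compound 3 to compound 4 (0.13 log units; within the scatter), is expected to stay near the scatter, with no direction favoured.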

Compound 4, inhibition constant: 38 nM
Estimate against measurement, compound 4: 92-fold (1.96 log units) above, and the stated range ends above it.
By their numbers in this assay, from the lowest: compound 4; then compounds 3, 1 and 2 (each within the scatter of the next).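

In this assay, the entering 1-(4-chloro-2-methylbenzyl)ethyl group gives a 68-fold lower number from compound 3 to compound 4 (1.84 log units; beyond the scatter), a 76-fold lower number from compound 1 to compound 4 (1.88 log units; beyond the scatter) and a 120-fold lower number from compound 2 to compound 4 (2.08 log units; beyond the scatter), all large and beyond the scatter. The earlier exchanges on the aryl ether ring left the number within the scatter, whereas this replacement of the whole group on the carbonyl carbon shows that the position can respond strongly. The replacement removes the ether oxygen and brings in the ring methyl and the chain branch together, so these steps cannot assign the gain to any one of them (nothing in the data shown explains the gain).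

Going by these compounds, whether an unbranched benzyl group or a 4-chloro-2-methylphenoxymethyl group would keep the gain remains open. So does the effect of an amine or a carboxylic acid on this ring.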